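The compounds below may be only part of what the source reports. "The series", "measured", "known", "first", "only" and "open" are said of these compounds alone.

Working notes on the series

The series starts from compound 1 `COc1ccc(S(=O)(=O)c2nc3ccccc3nc2Nc2cc(OC)cc(OC)c2)cc1`, which in a functional assay on HCT-116 cells (Homo sapiens) for cytotoxicity, read by MTT assay, with a stated time of 72 h (on this read-out higher numbers stand for weaker inhibition and lower numbers for stronger inhibition), gives 13400 nM. Two single changes to it are measured. Compound 2 `COc1ccc(S(=O)(=O)c2nc3ccccc3nc2Nc2ccc(N)cc2)cc1` carries the change 4-aminophenyl in place of 3,5-dimethoxyphenyl on a nitrogen on an aromatic ring and in this assay gives 6300 nM; the step is a 2.1-fold lower number from compound 1 to compound 2 (0.33 log units; beyond the scatter). Compound 3 `COc1cc(Nc2nc3ccccc3nc2S(=O)(=O)c2ccc(F)cc2)cc(OC)c1` carries the change fluoro in place of methoxy on an aromatic carbon and in this assay gives 3930 nM; the step is a 3.4-fold lower number from compound 1 to compound 3 (0.53 log units; beyond the scatter). Compound 2 and compound 3 are not separated by a single change, and their two numbers lie within the scatter of each other, so nothing is said about their order.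

Compound 4 `Nc1ccc(Nc2nc3ccccc3nc2S(=O)(=O)c2ccc(F)cc2)cc1` is not yet measured. Within the data shown here, it differs from compound 3 by 4-aminophenyl in place of 3,5-dimethoxyphenyl on a nitrogen on an aromatic ring, and the same change, measured once, is the one from compound 1 to compound 2, where it made a step of a 2.1-fold lower number from compound 1 to compound 2 (0.33 log units; beyond the scatter). The place of the change is described in the same words in both pairs; the cores differ by fluoro in place of methoxy on an aromatic carbon. Among the measured compounds shown here, on the only measured instance of this change, the step from compound 3 to compound 4 is expected to be a 2.1-fold lower number from compound 3 to compound 4 (0.32 log units; beyond the scatter), resting on the step of a 2.1-fold lower number from compound 1 to compound 2 (0.33 log units; beyond the scatter). Compound 4 is accordingly estimated at 1900 nM in this assay. The estimate for compound 4 is given a range from 800 nM to 4500 nM, since a single measured instance of the change on a different core leaves the transfer uncertain.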

Compound 4, half-maximal inhibitory concentration: 10100 nM
Compound 4: the middle estimate sits 5.3-fold (0.73 log units) below what was measured, and the stated range ends below it.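

With the group on the aromatic carbon fixed as fluoro, 4-aminophenyl in place of 3,5-dimethoxyphenyl gives a 2.6-fold higher number from compound 3 to compound 4 (0.41 log units; beyond the scatter), so in this assay this change does not carry over from the core of compound 1 to the core of compound 3 in either size or direction: the same change on two cores in this assay, a 2.1-fold lower number (0.33 log units; beyond the scatter) from compound 1 to compound 2 and a 2.6-fold higher number (0.41 log units; beyond the scatter) from compound 3 to compound 4, 5.5-fold (0.74 log units) apart, beyond the scatter of two such steps

Fluoro in place of methoxy does not carry over cleanly either, since with 4-aminophenyl on the nitrogen it gives a 1.6-fold higher number from compound 2 to compound 4 (0.20 log units; within the scatter), which shows no separation of the two numbers: the same change on two cores in this assay, a 3.4-fold lower number (0.53 log units; beyond the scatter) from compound 1 to compound 3 and a 1.6-fold higher number (0.20 log units; within the scatter) from compound 2 to compound 4, 5.5-fold (0.74 log units) apart, beyond the scatter of two such steps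

Among these compounds, these four compounds therefore show that the two changes do not add independently here, and no single step can be carried to the other core on its own; they do not show why, and each comparison rests on only two pairs in one cell assay.

From the compounds shown here alone, it remains open whether the same dependence would appear with other groups in place of the fluoro, such as chloro or trifluoromethyl. Going by these compounds, it is also open how a carboxylic acid or an amide in place of the amine on the 4-aminophenyl would behave on either core.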